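The source may hold more compounds than are shown below. What is called first, only, known or untested is meant among the compounds shown, and "the series" means these compounds.

Compound 1 `Cc1cccc(-c2nn(-c3ccc(F)cc3F)cc2CNCCN2CCN(C)CC2)c1` is the reference point in an ADME assay on Huh-7 cells (Homo sapiens) for cytotoxicity; a higher number here means that more compound is tolerated, a lower number that less compound is tolerated. In this assay compound 1 gives only a limit, > 20000 nM, so the compound sits at the limit of > 20000 nM in this assay, at which 1 of the 2 values shown sits, and no exact number is known for it. Compound 2 `CN1CCN(CCNCc2cn(-c3ccc(C(F)(F)F)cc3)nc2-c2ccc(OC(F)(F)F)cc2)CC1` differs in several places from the reference point; in this assay compound 2 gives 3000 nM. Compound 3 `CN1CCN(CCNCc2cn(-c3ccc(F)cc3F)nc2-c2cccc(N(C)C)c2)CC1` carries dimethylamino in place of methyl on an aromatic carbon relative to compound 1. For the measured compounds named here, no measured step of this kind exists; the step is expected to be small, at most a modest drop in tolerated concentration, an at least 1.3-fold lower number from compound 1 to compound 3 (0.12 log units; that floor lies within the scatter). Compound 3 is therefore estimated at 15000 nM, between 5000 nM and 30000 nM, with a real chance that the assay again reports only a limit.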

Compound 3, half-maximal cytotoxic concentration: > 20000 nM
Compound 3 gave a limit, no number (the forecaster's own chance of this, stated with the estimate: 45%); middle value at least 1.3-fold (0.12 log units) from the limit.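

Compound 1 and compound 3 yield no readable step, as both give a limit and not a number: the limit of > 20000 nM in this assay, at which 2 of the 3 values shown sit.

Still open, from the compounds shown here alone, is whether dimethylamino in place of methyl on an aromatic carbon changes the tolerated concentration at all, and in which direction.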